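Replacing a Pyridyl Ketone With an Ethylamide

A few compounds are considered here, and "the series" means these few. Any claim that something is new, unique, unknown or untested is made for them only; others in the source may bear on it.

Two compounds share one core and differ only in the group attached to the carbonyl carbon. Compound 1 `O=C(c1cncs1)c1nc(NCc2cccnc2)nc2ccsc12` carries a 1,3-thiazol-5-yl ring there, and in a functional assay on CHO-K1 cells for antagonist activity at adenosine receptor A2b (Homo sapiens), read by FLIPR and calcium flux (on this read-out lower numbers stand for stronger inhibition and higher numbers for weaker inhibition), compound 1 gives 148 nM. Compound 2 `O=C(c1ccncc1)c1nc(NCc2cccnc2)nc2ccsc12` carries a pyridin-4-yl ring instead, and in this assay compound 2 gives 869 nM. Among the measured compounds shown here, that exchange appears as a 5.9-fold higher number from compound 1 to compound 2 (0.77 log units; beyond the scatter), so compound 2 stands as the higher of the two numbers measured so far.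

Compound 3 `CCNC(=O)c1nc(NCc2cccnc2)nc2ccsc12` takes the change one step further: ethylamino in place of pyridin-4-yl on a carbonyl carbon. For the measured compounds named here, the ring that leaves is the same one that entered between compound 1 and compound 2, but an ethylamino group on a carbonyl carbon has no measured counterpart here, so the single known step gives only a loose guide. Because that step, a 5.9-fold higher number from compound 1 to compound 2 (0.77 log units; beyond the scatter), already moved the number upward when the ring at this position was changed, a further shift in the same direction is expected, though with wide uncertainty. The estimate for compound 3 in this assay is 1500 nM, within a range from 300 nM to 8000 nM, meaning an expected step of a 1.7-fold higher number from compound 2 to compound 3 (0.24 log units; within the scatter).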

Compound 3, half-maximal inhibitory concentration: 120 nM
Compound 3: middle estimate off by 13-fold (1.10 log units), on the high side, and the stated range ends above it.
By their numbers in this assay, from the lowest: compounds 3 and 1 (each within the scatter of the next); then compound 2.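

Both earlier compounds carry an aromatic ring on this carbonyl carbon, and they could not show whether such a ring is needed for a low number in this assay. Ethylamino, with no ring and 3 heavy atoms in place of the 6 of pyridin-4-yl, gives a 7.2-fold lower number from compound 2 to compound 3 (0.86 log units; beyond the scatter), and a 1.2-fold lower number from compound 1 to compound 3 (0.09 log units; within the scatter), so this open chain matches the 1,3-thiazol-5-yl ring within the scatter and the position accepts a ring-free amide as well as the better of the two rings. Nothing available explains why the number changes with this exchange.

Ethylamino differs from the rings in three ways at once, losing the ring, shrinking in size and bringing in the amide hydrogen, so the compounds shown cannot separate these changes; a dimethylamino group on the same carbonyl carbon, which has no amide hydrogen, would help to pull them apart. From the compounds shown here alone, how the number responds to the length of the chain also stays open, for instance with methylamino or propylamino in place of ethylamino.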